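The compounds below may be only part of what the source reports. "The series", "measured", "known", "first", "only" and "open" are said of these compounds alone.

The measured compounds, all in a functional assay on HL-60 cells (Homo sapiens) for cytotoxicity, with a stated time of 24 h; on this read-out lower numbers stand for higher toxicity in this test and higher numbers for lower toxicity in this test:

compound 1, `O=C1/C(=C/c2ccc(F)cc2)CCC/C1=C\c1cccc([N+](=O)[O-])c1`: compound 1 gives 1000 nM
compound 2, `O=C1/C(=C/c2ccc(Cl)cc2)CCC/C1=C\c1cccc([N+](=O)[O-])c1`: compound 2 gives 3200 nM
compound 3, `O=C1/C(=C/c2ccc(F)cc2)CCC/C1=C\c1ccc([N+](=O)[O-])cc1`: compound 3 gives 32000 nM

Compound 2 differs from compound 1 by one change, (chloro in place of fluoro on an aromatic carbon), and this change brought a 3.2-fold higher number from compound 1 to compound 2 (0.51 log units; beyond the scatter), a step beyond the usual scatter. Compound 3 has the same atoms as compound 1, joined differently; the difference between the two cores is not broken down here. Its number in this assay is the highest of the three, standing well apart from both compound 1 and compound 2.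

Compound 4, `O=C1/C(=C/c2ccc(Cl)cc2)CCC/C1=C\c1ccc([N+](=O)[O-])cc1`, has not yet been measured. It differs from compound 3 by chloro in place of fluoro on an aromatic carbon, the same change as that from compound 1 to compound 2, at the same kind of place. On that single earlier step, and only on it, compound 4 is expected to show a 2.8-fold higher number from compound 3 to compound 4 (0.45 log units; beyond the scatter) in this assay, a step of a size like that from compound 1 to compound 2, with wide uncertainty because the change has been seen once. The estimate for compound 4 is thus 90000 nM, between 30000 nM and 270000 nM.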

Compound 4, half-maximal cytotoxic concentration: 4100 nM
Estimate against measurement, compound 4: 22-fold (1.34 log units) above, and the stated range ends above it.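

On the core of compound 3, putting chloro in place of fluoro brought a 7.8-fold lower number from compound 3 to compound 4 (0.89 log units; beyond the scatter) in this assay, whereas on the core of compound 1 the same swap had raised the number. The two cores therefore answer this one change in opposite directions, and the gap between the two steps is real: the same change on two cores in this assay, a 3.2-fold higher number (0.51 log units; beyond the scatter) from compound 1 to compound 2 and a 7.8-fold lower number (0.89 log units; beyond the scatter) from compound 3 to compound 4, 25-fold (1.40 log units) apart, beyond the scatter of two such steps

For the compounds shown here, this means that a step seen on one core cannot simply be carried over to the other, but with only one pair on each core, it does not show why the two differ or how the change would behave on any further core.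

The compounds shown carry only fluoro or chloro on that aromatic ring, so it remains open whether bromo, a methoxy group or an amine in the same place would follow the pattern of either core. From the compounds shown here alone, it also remains open what a carboxylic acid in place of the nitro group would do in this test.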